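From 3,4,5-trimethoxyphenyl to thiophen-2-yl: expected growth inhibition

This account rests on a few compounds, and the source may have more. Where it says the series, first, only, none or still open, it means among the compounds named here.

- compound 1 `COc1cc(/C=C/C(=O)/C=C/c2ccccc2)ccc1OCc1cn(CCCCOc2cc(=O)oc3ccccc23)nn1` gives 34%
- compound 2 `COc1ccccc1/C=C/C(=O)/C=C/c1ccc(OCc2cn(CCCCOc3cc(=O)oc4ccccc34)nn2)c(OC)c1` gives 43%
- compound 3 `COc1cc(/C=C/C(=O)/C=C/c2cc(OC)c(OC)c(OC)c2)ccc1OCc1cn(CCCCOc2cc(=O)oc3ccccc23)nn1` gives 63%

These values come from a functional assay on HCT-116 cells (Homo sapiens) for inhibition, read by sulforhodamine B assay, with a stated time of 48 h, tested at 50 uM (on this read-out higher numbers stand for more inhibition of growth at the one concentration tested and lower numbers for less inhibition of growth), and compound 3 stands highest of the three. Putting 3,4,5-trimethoxyphenyl in place of phenyl gives a number 29 percentage points higher from compound 1 to compound 3 (beyond the scatter) and putting it in place of 2-methoxyphenyl gives a number 20 percentage points higher from compound 2 to compound 3 (beyond the scatter) while the single added methoxy gives only a number 9 percentage points higher from compound 1 to compound 2 (within the scatter) in the same read-out.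

Compound 4 `COc1cc(/C=C/C(=O)/C=C/c2cccs2)ccc1OCc1cn(CCCCOc2cc(=O)oc3ccccc23)nn1` changes the same place, a double-bonded chain carbon bound to a double-bonded chain carbon, and the difference from compound 3 is thiophen-2-yl in place of 3,4,5-trimethoxyphenyl on a double-bonded chain carbon bound to a double-bonded chain carbon in the structure. Like compound 1, compound 4 has no methoxy on that group, though no thiophen-2-yl compound has been measured yet. Compound 1 at 34% is therefore the nearest guide, and a drop of similar size to the gains above is expected. The estimated change is a number 25 percentage points lower from compound 3 to compound 4 (beyond the scatter) in this assay as a modest expected loss. Compound 4 is expected to give about 38% with an estimated range from 22% to 55% in this read-out.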

Compound 4, percent growth inhibition at one concentration: 41%
Compound 4: the middle estimate sits 3 percentage points below what was measured; low and high end bracket the measured number.
By their numbers in this assay, from the lowest: compounds 1, 4 and 2 (each within the scatter of the next); then compound 3.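

In this assay, thiophen-2-yl at this place, on a double-bonded chain carbon bound to a double-bonded chain carbon, does not keep the level reached with 3,4,5-trimethoxyphenyl, with a number 22 percentage points lower from compound 3 to compound 4 (beyond the scatter) in the read-out. The other two comparisons give a number 2 percentage points lower from compound 2 to compound 4 (within the scatter) and a number 7 percentage points higher from compound 1 to compound 4 (within the scatter), so among these four groups only 3,4,5-trimethoxyphenyl stands apart, while a five-membered sulfur-containing ring sits with phenyl and 2-methoxyphenyl. Nothing available explains why this group stands apart.

Going by these compounds, it remains open whether a ring with two methoxy groups would sit nearer to compound 3 or to the other three compounds. Also open, on these data alone, is how an amine or a carboxylic acid on the aromatic ring at this place would compare with compound 3.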